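A few compounds are considered here, and "the series" means these few. Any claim that something is new, unique, unknown or untested is made for them only; others in the source may bear on it.

In a functional assay on HeLa cells (Homo sapiens) for inhibition, read by CCK-8 assay, with a stated time of 48 h (on this read-out lower numbers stand for stronger inhibition and higher numbers for weaker inhibition), compound 1 `COc1cc(-c2cc3nccc(-c4cc(OC)c(OC)c(OC)c4)n3n2)cc(OC)c1OC` reads > 10000 nM, which is a limit of the assay and not a number. Compound 2 `COc1cc(-c2cc3nccc(-c4c[nH]c5ccccc45)n3n2)cc(OC)c1OC` reads > 10000 nM, which is again a limit. Among the compounds with values here, compound 3 `COc1cc(-c2ccnc3cc(-c4ccc(C)cc4)nn23)cc(OC)c1OC` gives 21 nM, the only true number among the three, so it is the single firm reference point. Compound 4 `COc1cc(-c2ccnc3cc(-c4cn(C)c5ccccc45)nn23)cc(OC)c1OC` keeps the core of compound 3 and changes one group, with 1-methyl-1H-indol-3-yl in place of 4-methylphenyl on an aromatic carbon. Within the data shown here, no measured step shows what such a swap does in this assay, so the expected step, a 1.2-fold higher number from compound 3 to compound 4 (0.08 log units; within the scatter), is none beyond the scatter, in either direction. For compound 4 the estimated value is 25 nM, with an expected range from 4 nM to 200 nM.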

Compound 4, half-maximal inhibitory concentration: 399 nM
Beside the measured number, compound 4's estimate is 16-fold (1.20 log units) below it; measured number outside the range, above it.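

Within the data shown here, the swap of 4-methylphenyl for 1-methyl-1H-indol-3-yl gives a 19-fold higher number from compound 3 to compound 4 (1.28 log units; beyond the scatter) in this assay and is the only step here that can be read, so the group on this aromatic carbon of the five-membered ring clearly changes the read-out. Compound 4 with 399 nM still gives a true number and not a limit of the assay. Nothing shown here explains the size of this step. Going by these compounds, how an amine, a carboxylic acid or a plain phenyl ring would read at this place stays open. On these data alone, whether the same swap would have a similar effect on a different core also stays open.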